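Swapping morpholine for piperidine on a thiosemicarbazide

The source may report more compounds than this note shows. Statements on the series, on what has been measured and on what is new or still open speak of the compounds shown alone.

Measured compounds:
compound 1 `Cc1cccc(/C(N)=N/NC(=S)N2CCSCC2)n1`, 80.7%
compound 2 `N/C(=N\NC(=S)N1CCCCC1)c1ccccn1`, 85.6%
compound 3 `Cc1cccc(/C(N)=N/NC(=S)N2CCOCC2)n1`, 84.8%

All three compounds were tested in a functional assay on A-431 cells (Homo sapiens) for cytotoxicity, read by MTT assay, with a stated time of 72 h, tested at 100 uM; on this read-out higher numbers stand for more inhibition of growth at the one concentration tested and lower numbers for less inhibition of growth. Compound 3 gives the second highest of the three numbers, but its gap to compound 2 and its gap to compound 1 both lie within the scatter, so the three compounds cannot be told apart on these data.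

Compound 4 `Cc1cccc(/C(N)=N/NC(=S)N2CCCCC2)n1` is not yet measured. It differs from compound 3 in one place: piperidin-1-yl in place of morpholin-4-yl on a thiocarbonyl carbon.

Going by the values given here, only one measured step touches the same position: a number 4.1 percentage points higher from compound 1 to compound 3 (within the scatter). There the group on the thiocarbonyl carbon changed and the read-out did not move beyond the scatter. Compound 2 carries piperidin-1-yl on its thiocarbonyl carbon, but on a different core, and in this assay compound 2 gives 85.6%, which is within the scatter of compound 3.

Compound 4 is therefore expected to give about 85%, with a range from 75% to 93%. This estimate means an expected step of a number 0.2 percentage points higher from compound 3 to compound 4 (within the scatter), which is expected not to exceed the scatter.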

Compound 4, percent growth inhibition at one concentration: 77.5%
Compound 4: the middle estimate sits 7.5 percentage points above what was measured, within the range that was stated.
By their numbers in this assay, from the lowest: compounds 4, 1, 3 and 2 (each within the scatter of the next).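

In this assay the shared core now carries morpholin-4-yl, thiomorpholin-4-yl or piperidin-1-yl on the thiocarbonyl carbon, and neither a number 7.3 percentage points lower from compound 3 to compound 4 (within the scatter) nor a number 3.2 percentage points lower from compound 1 to compound 4 (within the scatter) leaves the scatter, so these three rings cannot be told apart at this position. The result also opens a second place: a number 8.1 percentage points lower from compound 2 to compound 4 (within the scatter) shows that methyl in place of hydrogen on an aromatic carbon stays within the scatter as well. Nothing available explains these numbers, so no reason can be attached to them.

From the compounds shown here alone, all three groups on the thiocarbonyl carbon are six-membered non-aromatic rings, so what an open-chain group such as diethylamino or a ring bearing a free amine would give there remains open. Going by these compounds, because each compound was read at one concentration, it also remains open whether these compounds would differ at lower concentrations.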